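From 4-acetylphenyl to 3-amino-4-methoxyphenyl

The source may report more compounds than this note shows. Statements on the series, on what has been measured and on what is new or still open speak of the compounds shown alone.

Compound 1 `COc1cc(-c2ccnc3cc(-c4c[nH]c5ccccc45)nn23)cc(OC)c1OC`: 29 nM
Compound 2 `COc1cc(-c2ccnc3cc(-c4ccc(C(C)=O)cc4)nn23)cc(OC)c1OC`: 4100 nM

Both values come from a functional assay on A549 cells (Homo sapiens) for inhibition, read by CCK-8 assay, with a stated time of 48 h; on this read-out lower numbers stand for stronger inhibition and higher numbers for weaker inhibition. Compound 2, at 4100 nM, holds the higher of the two numbers and so is the weaker inhibitor of the pair. Compound 3 `COc1ccc(-c2cc3nccc(-c4cc(OC)c(OC)c(OC)c4)n3n2)cc1N` has 3-amino-4-methoxyphenyl in place of 4-acetylphenyl on an aromatic carbon. Within the data shown here, one measured step bears on this place, a 140-fold higher number from compound 1 to compound 2 (2.15 log units; beyond the scatter), which is large and beyond the scatter. The entering group itself has not been measured on this core, so the evidence is thin. A large step to a lower number is still expected in this assay, given that compound 1 reaches 29 nM with a different group at this place. Compound 3 is estimated at 50 nM, with an expected range of 10 nM to 400 nM. The expected change is an 82-fold lower number from compound 2 to compound 3 (1.91 log units; beyond the scatter).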

Compound 3, half-maximal inhibitory concentration: 138 nM
Estimate against measurement, compound 3: 2.8-fold (0.44 log units) below; low and high end bracket the measured number.
By their numbers in this assay, from the lowest: compound 1; then compound 3; then compound 2.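

In this assay, among these compounds, the change of 4-acetylphenyl to 3-amino-4-methoxyphenyl gives a 30-fold lower number from compound 2 to compound 3 (1.47 log units; beyond the scatter) at this place on the five-membered aromatic ring, so 1H-indol-3-yl is not the only group that brings the number well down, and a single six-membered aromatic ring of carbon only can also do so. The new group still falls short of 1H-indol-3-yl, with a 4.8-fold higher number from compound 1 to compound 3 (0.68 log units; beyond the scatter) on the same core. No measurement at hand offers an explanation for either step.

The compounds shown leave open whether the amine or the methoxy carries the gain, as the two appear only together on the ring. They also do not show how a hydroxyl in place of that amine would fare, or a methoxy added to the indole.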